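The compounds below may be only part of what the source reports. "The series", "measured", "known", "first", "only" and "open" are said of these compounds alone.

In a functional assay on WM 266-4 cells (Homo sapiens) for antiproliferative activity, read by MTT assay, with a stated time of 24 h (on this read-out higher numbers stand for weaker inhibition of growth and lower numbers for stronger inhibition of growth), compound 1 `O=C(c1ccc(Cl)nc1)N1N=C(c2ccc(Cl)cc2)CC1c1ccc(OCc2ccccc2)cc1` gives 13200 nM, and compound 2 `O=C(c1ccc(Cl)nc1)N1N=C(c2ccc(Cl)cc2)CC1c1ccc(Cl)cc1` gives 9890 nM. Going by the values given here, these two numbers lie within the scatter of each other, so compound 2 stands level with its only measured neighbour and neither can be ranked above the other. Compound 3 `O=C(c1ccc(Cl)nc1)N1N=C(c2ccc(Cl)cc2)CC1c1ccc(Br)cc1` differs from compound 2 in a single group: bromo in place of chloro on an aromatic carbon. Put simply, this is bromo in place of chloro on an aromatic carbon, turning a 4-chlorophenyl into a 4-bromophenyl. Among the compounds with values here, only one measured step bears on this change, at the same carbon, and it is a 1.3-fold lower number from compound 1 to compound 2 (0.13 log units; within the scatter). Even that exchange of a whole benzyloxy group for chloro stayed within the scatter, so swapping one halogen for another is expected to produce no step beyond the scatter in this assay. The expected step is a 1.0-fold lower number from compound 2 to compound 3 (0.02 log units; within the scatter). For compound 3, the estimated value is 9500 nM, with an expected range from 4500 nM to 20000 nM.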

Compound 3, concentration for 50% growth inhibition: 9870 nM
Beside the measured number, compound 3's estimate is 1.0-fold (0.02 log units) below it; the measured number falls inside the stated range.
By their numbers in this assay, from the lowest: compounds 3, 2 and 1 (each within the scatter of the next).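

The step of a 1.0-fold lower number from compound 2 to compound 3 (0.00 log units; within the scatter) places the two halogens level in this assay, and the step of a 1.3-fold lower number from compound 1 to compound 3 (0.13 log units; within the scatter) places bromo level with benzyloxy as well. Going by these compounds alone, this carbon has now carried three different groups, benzyloxy and two single halogen atoms, and all three compounds read alike, where before only one pair could be compared. Nothing measured here explains this evenness.

As far as these compounds go, whether a group of another kind on this carbon, such as an amine or a carboxylic acid, would give a step beyond the scatter stays open. So does the part played by the rest of the core, which is the same in all three compounds.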